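The source may report more compounds than this note shows. Statements on the series, on what has been measured and on what is new or still open speak of the compounds shown alone.

Of the compounds shown here, three sharing one core have been measured in a functional assay on HCT-116 cells (Homo sapiens) for antiproliferative activity, read by MTT assay, with a stated time of 48 h; a lower number here means a stronger inhibitor, a higher number a weaker inhibitor. Compound 1 `COc1cccc(C(=O)Nc2cccc(/C=C/C(=O)c3nc4ccccc4[nH]3)c2)c1` gives 3680 nM, compound 2 `O=C(/C=C/c1cccc(NS(=O)(=O)c2ccccc2Cl)c1)c1nc2ccccc2[nH]1` gives 987 nM, and compound 3 `O=C(/C=C/c1cccc(NS(=O)(=O)c2ccc(Cl)cc2)c1)c1nc2ccccc2[nH]1` gives 1960 nM, the second highest number of the three and within the scatter of both others, since a 1.9-fold lower number from compound 1 to compound 3 (0.27 log units; within the scatter) and a 2.0-fold higher number from compound 2 to compound 3 (0.30 log units; within the scatter). Compound 4 `O=C(/C=C/c1cccc(NS(=O)(=O)c2cc(Cl)cc(Cl)c2)c1)c1nc2ccccc2[nH]1` differs from compound 3 only in that (3,5-dichlorophenyl in place of 4-chlorophenyl on a sulfonyl sulfur). Going by the values given here, the single measured step at the same sulfonyl sulfur, a 2.0-fold higher number from compound 2 to compound 3 (0.30 log units; within the scatter), stayed within the scatter, so adding a second chlorine to the phenyl on that sulfur is expected to move this assay little, if at all. Compound 4 is therefore expected to give 1500 nM, between 500 nM and 4500 nM. This expected step, a 1.3-fold lower number from compound 3 to compound 4 (0.12 log units; within the scatter), is expected to stay within the scatter.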

Compound 4, half-maximal inhibitory concentration: 2840 nM
Beside the measured number, compound 4's estimate is 1.9-fold (0.28 log units) below it; measured number inside the range.
By their numbers in this assay, from the lowest: compounds 2, 3, 4 and 1 (each within the scatter of the next, the first and the last beyond it).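

In this assay, replacing 4-chlorophenyl with 3,5-dichlorophenyl on the sulfonyl sulfur stays within the usual scatter (a 1.4-fold higher number from compound 3 to compound 4 (0.16 log units; within the scatter)). Going by these compounds alone, replacing 2-chlorophenyl with the same group gives the first step at this position that goes beyond the scatter, though only modestly (a 2.9-fold higher number from compound 2 to compound 4 (0.46 log units; beyond the scatter)). Nothing available explains either step. The compounds shown cover only chlorinated phenyl groups on that sulfur, so they leave open what a phenyl carrying an amine or a carboxylic acid, or a methyl group replacing the phenyl, would do.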